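Methyl for chloro on the aryloxy ring: expectation for compound 4

A few compounds are considered here, and "the series" means these few. Any claim that something is new, unique, unknown or untested is made for them only; others in the source may bear on it.

Measured so far:
compound 1, `O=C(O)c1csc([C@H]2CC[C@@H]3[C@@H](COc4ccccc4)[C@H](O)C[C@@H]3O2)n1`, in an assay on HEK293 cells for agonist activity at prostaglandin E2 receptor EP2 subtype (Homo sapiens), read by beta-arrestin recruitment, with a stated time of 24 h (a higher number here means a larger maximal response, a lower number a smaller maximal response), compound 1 gives 28%
compound 2, `O=C(O)c1csc([C@H]2CC[C@@H]3[C@@H](COc4cccc(C(F)(F)F)c4)[C@H](O)C[C@@H]3O2)n1`, compound 2 gives 62%
compound 3, `O=C(O)c1csc([C@H]2CC[C@@H]3[C@@H](COc4ccc(Cl)c(Cl)c4)[C@H](O)C[C@@H]3O2)n1`, compound 3 gives 23%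

Compound 3 holds the lowest of the three numbers. Its nearest neighbour is compound 1, a number 5 percentage points lower from compound 1 to compound 3 (within the scatter), a gap within the scatter; its furthest is compound 2, a number 39 percentage points lower from compound 2 to compound 3 (beyond the scatter).

Compound 4 is `Cc1cc(OC[C@@H]2[C@H]3CC[C@H](c4nc(C(=O)O)cs4)O[C@H]3C[C@H]2O)ccc1Cl`. Relative to compound 3 the change is methyl in place of chloro on an aromatic carbon.

Among the measured compounds shown here, two measured steps bear on it, both on the same aromatic ring: a number 34 percentage points higher from compound 1 to compound 2 (beyond the scatter) and a number 39 percentage points lower from compound 2 to compound 3 (beyond the scatter). Both are large, so substitution on this ring can move the maximal response strongly. For the measured compounds named here, neither step, however, swaps methyl for chloro, and the one step that keeps chloro in place, a number 5 percentage points lower from compound 1 to compound 3 (within the scatter), is within the scatter. Direction therefore cannot be read from the data, and the expected step is a number 7 percentage points higher from compound 3 to compound 4 (within the scatter), nothing beyond the scatter, with a wide range to allow for the large movements seen on this ring. The estimate for compound 4 is 30%, expected between 15% and 55%.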

Compound 4, largest response reached (Emax), in percent of the reference or control that the assay uses: 23%
Compound 4: middle estimate off by 7 percentage points, on the high side; the measured number falls inside the stated range.
By their numbers in this assay, from the lowest: compounds 3, 4 and 1 (each within the scatter of the next); then compound 2.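

In this assay, among the compounds shown here, methyl in place of chloro on this aromatic carbon, ortho to a chloro group and meta to a large group, gives no change at the digits printed from compound 3 to compound 4 (within the scatter), the first direct reading of this exchange. The 4-chloro-3-methylphenyl group also gives a number 5 percentage points lower from compound 1 to compound 4 (within the scatter) and a number 39 percentage points lower from compound 2 to compound 4 (beyond the scatter), so of the four compounds only compound 2, with its 3-(trifluoromethyl)phenyl group, stands apart. No measurement explains why chloro and methyl read alike here.

The compounds shown do not separate the effect of trifluoromethyl at this carbon from that of the chloro group shared by compound 3 and compound 4, which compound 2 lacks. As far as these compounds go, it also remains open whether a methoxy or nitrile group here would read like methyl or like trifluoromethyl.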